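The source may report more compounds than this note shows. Statements on the series, on what has been measured and on what is new or still open speak of the compounds shown alone.

Values in a functional assay on MDA-MB-231 cells (Homo sapiens) for antiproliferative activity, read by MTT assay, with a stated time of 48 h; on this read-out higher numbers stand for weaker inhibition and lower numbers for stronger inhibition:
- Compound 1 `C=CS(=O)(=O)N1CCN(c2nc(OC[C@H]3CCCN3C)nc3sccc23)CC1`: > 50000 nM, a limit of the assay and not a number
- Compound 2 `CCS(=O)(=O)N1CCN(c2ncnc3sc(-c4ccc(N5CCN(C)CC5)cc4)cc23)CC1`: 7330 nM
- Compound 3 `CCCNC(=O)N1CCN(c2ncnc3sc(-c4ccc(N5CCN(C)CC5)cc4)cc23)CC1`: 8330 nM

Within the data shown here, compound 3 holds the higher of the two actual numbers in this assay, at 8330 nM, but that position means little: its only numerical neighbour is compound 2 at 7330 nM, and the two lie within the scatter of each other. The next structure, compound 4 `CN1CCN(c2ccc(-c3cc4c(N5CCN(C(=O)Nc6ccc(OC(F)(F)F)cc6)CC5)ncnc4s3)cc2)CC1`, carries 4-(trifluoromethoxy)phenyl in place of propyl on an amide-type nitrogen.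

Among the measured compounds shown here, only one measured step bears on this change. Putting propylcarbamoyl in place of ethylsulfonyl on an amine nitrogen in a ring gave a 1.1-fold higher number from compound 2 to compound 3 (0.06 log units; within the scatter), a step within the scatter. That step concerns the same side of the molecule, but it does not introduce an aromatic ring, so it offers only weak guidance for compound 4. For the measured compounds named here, the limit of compound 1 provides no step to compare. The exchange is larger than the one already measured, so a modest move toward a lower number is expected, with considerable uncertainty, and a result near compound 3 remains quite possible.

The expected change is a 2.1-fold lower number from compound 3 to compound 4 (0.32 log units; beyond the scatter). For compound 4 the estimate is 4000 nM, with an expected range from 1200 nM to 14000 nM.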

Compound 4, half-maximal inhibitory concentration: 4600 nM
For compound 4 the middle estimate is 1.2-fold (0.06 log units) below the measured one, and the stated range covers the measured number.
By their numbers in this assay, from the lowest: compounds 4, 2 and 3 (each within the scatter of the next). At a limit, above all of these: compound 1.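

In this assay, the exchange of propyl for 4-(trifluoromethoxy)phenyl on an amide-type nitrogen amounts to a 1.8-fold lower number from compound 3 to compound 4 (0.26 log units; within the scatter), so compound 3 and compound 4 cannot be told apart at this position. The earlier step, a 1.1-fold higher number from compound 2 to compound 3 (0.06 log units; within the scatter), concerned only the group on the ring nitrogen and brought in no aromatic ring, whereas this one shows that a six-membered aromatic ring of carbon can stand on the amide-type nitrogen, with 11 heavy atoms entering for 3, without a step beyond the scatter. The change in size and the aromatic ring thus leave the number within the scatter, though a single step cannot establish a general tolerance at this position, and no measurement shown bears on a cause for this outcome.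

The compounds shown leave open whether phenyl without the trifluoromethoxy group would read like compound 4, and so whether the ring or its substituent matters more here. They also leave open how a longer alkyl chain, an amine or a carboxylic acid in this place would read in this assay, and whether any such group would give a step beyond the scatter.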